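Swapping one fluorinated group for another on a shared core

The source may hold more compounds than are shown below. What is called first, only, known or untested is meant among the compounds shown, and "the series" means these compounds.

Compound 1 `CC(O)(CSc1cccc(S(F)(F)(F)(F)F)c1)C(=O)Nc1cccc(S(F)(F)(F)(F)F)c1` and compound 2 `CC(O)(CSc1cccc(C(F)(F)F)c1)C(=O)Nc1cccc(S(F)(F)(F)(F)F)c1` share one core; compound 3 `CC(O)(COc1cccc(S(F)(F)(F)(F)F)c1)C(=O)Nc1ccc(S(F)(F)(F)(F)F)cc1` and compound 4 `CC(O)(COc1cccc(C(F)(F)F)c1)C(=O)Nc1ccc(S(F)(F)(F)(F)F)cc1` share another, and the difference between the two cores is not broken down here. In a functional assay on CWR22R cells (Homo sapiens) for antiproliferative activity, read by propidium iodide staining, with a stated time of 96 h (a lower number here means a stronger inhibitor, a higher number a weaker inhibitor), compound 1 gives 17200 nM, compound 2 gives 12900 nM, and compound 3 gives 17600 nM.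

Within the first pair, the change a group of 4 heavy atoms (1 carbon, 3 fluorine; no ring) in place of a group of 6 heavy atoms (5 fluorine, 1 sulfur; no ring), on an aromatic carbon made a step of a 1.3-fold lower number from compound 1 to compound 2 (0.12 log units; within the scatter). The same change, (a group of 4 heavy atoms (1 carbon, 3 fluorine; no ring) in place of a group of 6 heavy atoms (5 fluorine, 1 sulfur; no ring), on an aromatic carbon), turns compound 3 into compound 4, and the place where it happens is described in the same words for both pairs. As it has been seen only once, the expectation for compound 4 rests on that one step alone, read against the value of compound 3 17600 nM.

In this assay compound 4 is therefore expected to move by about a 1.3-fold lower number from compound 3 to compound 4 (0.10 log units; within the scatter), a step like the earlier one and within the scatter. The estimate for compound 4 is 14000 nM, expected to lie between 7000 nM and 28000 nM.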

Compound 4, half-maximal inhibitory concentration: 14600 nM
The estimate for compound 4 lay 1.0-fold (0.02 log units) below the measured number; the measured number falls inside the stated range.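

In this assay, replacing the group of five fluorine atoms and one sulfur atom with trifluoromethyl gives a 1.2-fold lower number from compound 3 to compound 4 (0.08 log units; within the scatter), so on this second core the swap again leaves the number inside the usual spread of repeated measurements. The two cores agree closely on this change: the same change on two cores in this assay, a 1.3-fold lower number (0.12 log units; within the scatter) from compound 1 to compound 2 and a 1.2-fold lower number (0.08 log units; within the scatter) from compound 3 to compound 4, 1.1-fold (0.04 log units) apart, within the scatter of two such steps

This shows that, for these two pairs, the swap carries from one core to the other with no detectable shift in antiproliferative activity. It does not show that a change with a clear effect would carry over in the same way, and two pairs cannot speak for the whole series.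

The compounds shown leave open whether another group on that aromatic carbon, such as a nitrile, a chlorine atom or a carboxylic acid, would move the number at all. They also leave open how the two cores compare with each other, as no pair shown links them through a single difference.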